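Trimming the side chain: compound 2 to compound 3

This account rests on a few compounds, and the source may have more. Where it says the series, first, only, none or still open, it means among the compounds named here.

The series shares one core, seen in compound 1 `COCC(C(=O)N1CCN(c2cccc(C(F)(F)F)c2)CC1)N1C(=O)CCC1=O` and compound 2 `CCC(C(=O)N1CCN(c2cccc(C(F)(F)F)c2)CC1)N1C(=O)CCC1=O`. In a functional assay on the whole organism (strain Swiss) with Mus musculus as the target, with a stated time of 0.25 h, at a dose of 100 mg/kg (on this read-out lower numbers stand for a weaker effect and higher numbers for a stronger effect at the one dose given), compound 1 gives 50%. Compound 2 gives 50% in this assay. Among the measured compounds shown here, the one measured step, no change at the digits printed from compound 1 to compound 2 (within the scatter), is a methyl in place of methoxy on a saturated chain carbon, two bonds along the chain from an amide-type nitrogen in a ring and a carbonyl carbon. Compound 2 thus stands level with compound 1 at the digits shown; no measured pair separates the two.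

Compound 3 `CC(C(=O)N1CCN(c2cccc(C(F)(F)F)c2)CC1)N1C(=O)CCC1=O` is the next compound awaiting measurement. It differs from compound 2 in one place: hydrogen in place of methyl on a saturated chain carbon, two bonds along the chain from an amide-type nitrogen in a ring and a carbonyl carbon. For the measured compounds named here, the single measured step bears on it only loosely: it altered a group at the same chain carbon, and the read-out did not move beyond the scatter. Going by the values given here, no step yet shows what removing a carbon at this position does. The estimated step is no change at the digits printed from compound 2 to compound 3 (within the scatter), expected because compound 2 stands at 50% and because no change at the digits printed from compound 1 to compound 2 (within the scatter) shows the earlier change at this carbon stayed within the scatter. Compound 3 is therefore expected to give 50% in this assay, with a range from 35% to 65%.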

Compound 3, a percentage reported as activity, at one dose (the size of the read-out at that dose, not a potency): 50%
Estimate against measurement, compound 3: no gap at the digits printed; low and high end bracket the measured number.
By their numbers in this assay, from the lowest: compounds 1, 2 and 3 (each within the scatter of the next).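

Among the compounds shown here, with hydrogen in place of methyl on this saturated chain carbon, this assay gives no change at the digits printed from compound 2 to compound 3 (within the scatter), so shortening ethyl to methyl leaves the read-out where it stood, and the first step that removes a carbon here shows no effect beyond the scatter. Hydrogen in place of methoxy gives no change at the digits printed from compound 1 to compound 3 (within the scatter), which extends the earlier single comparison to all the pairs among these three compounds: none of the changes at this carbon separates one compound from another in this assay. No measurement on hand bears on why the read-out stays flat across these changes.

Whether an amine, a carboxylic acid or a longer chain such as butyl at this carbon would move the read-out remains open, as the compounds shown cover only a narrow set of small groups. Also open, on these data alone, is whether the three compounds would stay level at other doses or times, since a reading at one dose is a size of effect and not a potency, and equal readings here need not mean equal potency.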